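The source may report more compounds than this note shows. Statements on the series, on what has been measured and on what is new or still open speak of the compounds shown alone.

Measured so far:
- compound 1, `O=C(/C(=C\c1ccccc1F)S(=O)(=O)c1ccc(Br)cc1)c1ccc(Cl)cc1`, gives 25000 nM in a functional assay on DU-145 cells (Homo sapiens) for inhibition, read by trypan blue exclusion, with a stated time of 96 h; a higher number here means a weaker inhibitor of growth, a lower number a stronger inhibitor of growth
- compound 2, `Cc1ccc(S(=O)(=O)/C(=C/c2ccccc2F)C(=O)c2ccc(Cl)cc2)cc1`, gives 2500 nM in this assay
- compound 3, `O=C(/C(=C\c1ccccc1OCc1ccccc1)S(=O)(=O)c1ccc(Br)cc1)c1ccc(Cl)cc1`, gives 1000 nM in this assay

Among these three, compound 1 stands with the highest number, so it is the weakest growth inhibitor of the set. Its nearest neighbour is compound 2, reached by the step of a 10-fold lower number from compound 1 to compound 2 (1.00 log units; beyond the scatter); its furthest is compound 3, reached by the step of a 25-fold lower number from compound 1 to compound 3 (1.40 log units; beyond the scatter), a change of the fluoro carried by the 2-fluorophenyl group.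

The unmeasured compound 4, `O=C(/C(=C\c1ccc(Cl)cc1Cl)S(=O)(=O)c1ccc(Br)cc1)c1ccc(Cl)cc1`, differs from compound 1 in one place: 2,4-dichlorophenyl in place of 2-fluorophenyl on a double-bonded chain carbon bound to a double-bonded chain carbon. Within the data shown here, of the two measured steps, the one from compound 1 to compound 3 bears most on this, since it also alters the 2-fluorophenyl group, and it was large. The step from compound 1 to compound 2 changed a different ring and was modest. The change to a 2,4-dichlorophenyl group is, however, not the same as adding benzyloxy, so only a weaker improvement is expected. Compound 4 is therefore estimated to reach 8000 nM in this assay, within a range from 2500 nM to 25000 nM, which would amount to an expected step of a 3.1-fold lower number from compound 1 to compound 4 (0.49 log units; beyond the scatter).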

Compound 4, concentration for 50% growth inhibition: 50000 nM
Estimate against measurement, compound 4: 6.3-fold (0.80 log units) below; measured number above the stated range.
By their numbers in this assay, from the lowest: compound 3; then compound 2; then compounds 1 and 4 (each within the scatter of the next).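

In this assay, putting 2,4-dichlorophenyl in place of 2-fluorophenyl on a double-bonded chain carbon bound to a double-bonded chain carbon gives a 2.0-fold higher number from compound 1 to compound 4 (0.30 log units; within the scatter), so this change cannot be told apart from no change at all. The earlier step of a 25-fold lower number from compound 1 to compound 3 (1.40 log units; beyond the scatter) showed that a change on this same ring can matter greatly, while the new pair shows that a change here does not by itself bring a stronger inhibitor of growth: swapping the ring's halogen pattern leaves the number where it was, and only the benzyloxy compound stands apart among the changes on this ring. The data hold no measurement that could explain why these two changes on one ring end so differently.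

The compounds shown leave open how much of the benzyloxy gain needs the whole group, since a smaller ether such as methoxy, or an amine, in place of the fluoro would separate the oxygen from the second ring. They also leave open whether the gain from methyl in place of bromo on the other ring would add to a change on this ring.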